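The source may report more compounds than this note shows. Statements on the series, on what has been measured and on what is new or still open speak of the compounds shown alone.

Measured so far in a functional assay on HOS cells (Homo sapiens) for inhibition, with a stated time of 72 h; a lower number here means a stronger inhibitor, a higher number a weaker inhibitor:
- compound 1 `NC1CCC(Nc2nc(NCc3ccc(-c4ccsc4)cc3)c3ncn(C4CCCC4)c3n2)CC1`: 120 nM
- compound 2 `NC1CCC(Nc2nc(NCc3ccc(-c4cccc(F)c4)nc3)c3ncn(C4CCCC4)c3n2)CC1`: 44 nM

Of these two, compound 2 has the lower number, at 44 nM, and so is the stronger inhibitor. The gap to compound 1, at 120 nM, lies beyond the usual scatter of repeated measurements. However, these two compounds differ in more than one place, so their gap says little about any single group.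

Compound 3 `NC1CCC(Nc2nc(NCc3ccc(-c4ccccc4O)nc3)c3ncn(C4CCCC4)c3n2)CC1` has not yet been measured in this assay. It keeps the shared core of compound 2 and changes one group: 2-hydroxyphenyl in place of 3-fluorophenyl on an aromatic carbon. This is 2-hydroxyphenyl in place of 3-fluorophenyl, on an aromatic carbon of a six-membered aromatic ring with 1 nitrogen, next to the ring nitrogen and para to a large group.

Going by the values given here, no measured pair shows what this kind of swap does, so any forecast is uncertain and the range must be wide. Since the entering group is again a phenyl ring, only a small loss is expected. The estimated change is a 1.6-fold higher number from compound 2 to compound 3 (0.20 log units; within the scatter), which would probably stay within the scatter. For compound 3 the expected value is 70 nM, with an estimated range from 20 nM to 250 nM.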

Compound 3, half-maximal inhibitory concentration: 14 nM
Beside the measured number, compound 3's estimate is 5.0-fold (0.70 log units) above it; measured number outside the range, below it.
By their numbers in this assay, from the lowest: compound 3; then compound 2; then compound 1.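

In this assay, going by these compounds alone, the change from 3-fluorophenyl to 2-hydroxyphenyl on this aromatic carbon, next to the ring nitrogen and para to a large group, gives a 3.1-fold lower number from compound 2 to compound 3 (0.50 log units; beyond the scatter) and is the first comparison here between compounds that differ in one place only. It shows that the group at this position can shift the number beyond the usual scatter, even between two groups of equal heavy-atom count that each hold a six-membered aromatic ring of carbon only. The entering group has 1 hydrogen-bond donor and 1 hydrogen-bond acceptor where the leaving group has 0 of each, but no measurement here explains the gain.

This single swap changes both the substituent on the phenyl ring and its location, so the compounds shown cannot separate the effect of the hydroxyl group from that of its placement. A 3-hydroxyphenyl group and a 2-fluorophenyl group would each change only one of these, and a 2-methoxyphenyl group would test whether the hydroxyl hydrogen matters.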